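The source may report more compounds than this note shows. Statements on the series, on what has been measured and on what is new or still open speak of the compounds shown alone.

Compound 1 `O=c1[nH]c(=O)n(CCC(CO)CO)cc1C#Cc1cc(F)cc(F)c1` gives > 100000 nM in a functional assay on SW-620 cells (Homo sapiens) for antiproliferative activity, read by MTT assay, with a stated time of 72 h (on this read-out higher numbers stand for weaker inhibition and lower numbers for stronger inhibition), which is a limit of the assay.
Compound 2 `O=c1[nH]c(=O)n(CCC(CO)CO)cc1C#Cc1ccc(Br)cc1` gives > 100000 nM in this assay, again only a limit.

Compound 2 therefore stands at the limit, where compound 1 also sits (the limit of > 100000 nM in this assay, at which 2 of the 2 values shown sit), and the step that the two limits leave unreadable from compound 1 to compound 2 cannot be read from the two limits. Compound 3 `O=c1[nH]c(=O)n(CCC(CO)CO)cc1C#CCc1ccccc1` carries benzyl in place of 4-bromophenyl on a triple-bonded carbon. Among the measured compounds shown here, no measured step gives a readable size for this change, so the expected step of a number no higher from compound 2 to compound 3 (the limit leaves the size open) is none beyond the scatter. Compound 3 is expected to give 100000 nM, with a range of 20000 nM to 300000 nM, and most probably to be reported as a limit as well.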

Compound 3, half-maximal inhibitory concentration: 72400 nM
Estimate against measurement, compound 3: 1.4-fold (0.14 log units) above; measured number inside the range.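

Of the three compounds, only compound 3, with benzyl on the triple-bonded carbon, gives a number rather than a limit in this assay. Going by these compounds, the change gives an at least 1.3-fold lower number from compound 2 to compound 3 (0.14 log units; that floor lies within the scatter) and an at least 1.3-fold lower number from compound 1 to compound 3 (0.14 log units; that floor lies within the scatter), so these floors show no gain beyond the scatter, and the true size of each step stays unknown. The other two compounds remain limits: the limit of > 100000 nM in this assay, at which 2 of the 3 values shown sit.

The compounds shown leave open whether an amine or a carboxylic acid on the benzyl group, or a longer chain in its place, would move the number clearly lower in this assay.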